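A few compounds are considered here, and "the series" means these few. Any claim that something is new, unique, unknown or untested is made for them only; others in the source may bear on it.

Measured so far in a functional assay on MCF7 cells (Homo sapiens) for cytotoxicity, read by MTT assay, with a stated time of 48 h; on this read-out higher numbers stand for weaker inhibition and lower numbers for stronger inhibition:
- Compound 1 `C/C(=N/NC(=S)Nc1ccccc1)c1ccccn1`: 0.18 nM
- Compound 2 `C/C(=N/NC(=S)Nc1ccc([N+](=O)[O-])cc1)c1ccccn1`: 52 nM

Of these two compounds, compound 2 has the higher value, 52 nM, so it is the weaker inhibitor in this assay. Compound 3 `C/C(=N/NC(=S)Nc1ccc(F)cc1)c1ccccn1` replaces its nitro with fluoro on an aromatic carbon, para to a large group: fluoro in place of nitro on an aromatic carbon. Within the data shown here, only one measured step bears on this change: a 290-fold higher number from compound 1 to compound 2 (2.46 log units; beyond the scatter), where nitro took the place of hydrogen at that same kind of carbon. Removing the nitro may therefore undo much of that large rise. Fluoro is not hydrogen, however, and no measured compound carries it, so a full return is not assumed. The expected change is a 26-fold lower number from compound 2 to compound 3 (1.41 log units; beyond the scatter). For compound 3 the estimated value is 2 nM, with an expected range from 0.2 nM to 20 nM.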

Compound 3, half-maximal inhibitory concentration: 1.2 nM
Estimate against measurement, compound 3: 1.7-fold (0.22 log units) above; the measured number falls inside the stated range.
By their numbers in this assay, from the lowest: compound 1; then compound 3; then compound 2.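

In this assay, fluoro in place of nitro on this aromatic carbon gives a 43-fold lower number from compound 2 to compound 3 (1.64 log units; beyond the scatter) and so recovers most of the loss seen with nitro. This shows that the outcome at this position depends strongly on which group sits there, not only on whether hydrogen has been replaced. Even so, fluoro does not fully match hydrogen: the change gives a 6.7-fold higher number from compound 1 to compound 3 (0.82 log units; beyond the scatter) and this smaller step is still beyond the usual scatter of the assay. Nothing available explains why these two groups differ so much.

With only hydrogen, fluoro and nitro shown here, it remains open where a chlorine, a methoxy group or an amine at this carbon would fall. Going by these compounds, it is also open whether fluoro would give a similar result at another carbon of the same ring.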